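This account rests on a few compounds, and the source may have more. Where it says the series, first, only, none or still open, it means among the compounds named here.

Within the data shown here, in a functional assay on HCC827 cells (Homo sapiens) for antiproliferative activity, read by CCK-8 assay, with a stated time of 72 h (on this read-out higher numbers stand for weaker inhibition and lower numbers for stronger inhibition), compound 1 (`C#Cc1cccc(Nc2ncnc3cc(OCCOC(=O)c4ccccc4OC(C)=O)c(OCCOC)cc23)c1`) gives 100 nM, the lower of the two numbers so far, while compound 2 (`C#Cc1cccc(Nc2ncnc3cc(OCCOC(=O)C(C)c4ccc(CC(C)C)cc4)c(OCCOC)cc23)c1`) gives 400 nM. Compound 3 (`C#Cc1cccc(Nc2ncnc3cc(OCCOC(=O)c4ccccc4OC(C)=O)c(OCCOC(=O)c4ccccc4OC(C)=O)cc23)c1`) matches compound 1 except at one place: (2-acetoxyphenyl)carbonyl in place of methyl on an oxygen on a saturated carbon. In words, (2-acetoxyphenyl)carbonyl stands in place of methyl on an oxygen on a saturated carbon, so that compound 3 carries this group twice. Among the measured compounds shown here, only one measured step bears on the change, and only indirectly: a 4.0-fold higher number from compound 1 to compound 2 (0.60 log units; beyond the scatter). That modest step replaced one group on a carbonyl carbon with another and left the methyl untouched. For the measured compounds named here, no measured compound shows a change at the methyl itself, so the evidence is thin. Going by the values given here, on that basis, a modest rise in the number, meaning weaker inhibition, is expected, of about the same size as the one measured step, although a result within the scatter remains possible. The estimated step is a 3.0-fold higher number from compound 1 to compound 3 (0.48 log units; beyond the scatter). Compound 3 is estimated at 300 nM, with an expected range from 80 nM to 1000 nM.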

Compound 3, half-maximal inhibitory concentration: 900 nM
Estimate against measurement, compound 3: 3.0-fold (0.48 log units) below; measured number inside the range.
By their numbers in this assay, from the lowest: compound 1; then compound 2; then compound 3.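

In this assay, among these compounds, this is the first change measured at the oxygen on a saturated carbon, and replacing methyl with (2-acetoxyphenyl)carbonyl gives a 9.0-fold higher number from compound 1 to compound 3 (0.95 log units; beyond the scatter), beyond the usual scatter. The position therefore responds to what it carries, and here the larger group goes with weaker inhibition, a link that rests on this single pair. The change brings in 12 heavy atoms, one six-membered aromatic ring and 3 hydrogen-bond acceptors at once, so the step cannot tie the rise to any one of these features, and no supporting measurement accounts for it.

The compounds shown leave open how the number would move with a simpler group at this oxygen, such as an ethyl group, a longer carbon chain, a chain ending in an amine or one ending in a carboxylic acid, and whether any of these would stay close to compound 1. They also leave open whether 1-(4-isobutylphenyl)ethyl on a carbonyl carbon, placed at this same oxygen, would shift the number in the same direction as (2-acetoxyphenyl)carbonyl does.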